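Bromo-fluoro aryl variation on the amide series

The source may report more compounds than this note shows. Statements on the series, on what has been measured and on what is new or still open speak of the compounds shown alone.

Measured compounds in a functional assay on A549 cells (Homo sapiens) for antiproliferative activity, read by MTT assay, with a stated time of 72 h; a lower number here means a stronger inhibitor, a higher number a weaker inhibitor:
- compound 1 `O=C(Nc1ccc(Oc2ccnc3[nH]ccc23)cc1)c1cc2cccnc2n(-c2ccc(F)cc2)c1=O`: 210 nM
- compound 2 `O=C(Nc1ccc(Oc2ccnc3[nH]ccc23)cc1)c1cc2cccnc2n(-c2ccc(Br)cc2)c1=O`: 280 nM
- compound 3 `Cn1ccc2c(Oc3ccc(NC(=O)c4cc5cccnc5n(-c5ccc(F)cc5)c4=O)cc3)ccnc21`: 210 nM

Compound 3 sits level with compound 1 in this assay, and the two together give the lowest of the three numbers; compound 2 lies a 1.3-fold higher number from compound 1 to compound 2 (0.12 log units; within the scatter) from compound 1, a gap that stays within the scatter. The methylation step, no change at the digits printed from compound 1 to compound 3 (within the scatter), also stays within the scatter.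

Compound 4 `Cn1ccc2c(Oc3ccc(NC(=O)c4cc5cccnc5n(-c5ccc(Br)cc5F)c4=O)cc3)ccnc21` keeps the methylated core of compound 3 and changes only the aryl group on the ring nitrogen: 4-bromo-2-fluorophenyl in place of 4-fluorophenyl on an aromatic nitrogen. Among the measured compounds shown here, the one measured step that bears on this is the bromo-for-fluoro exchange, a 1.3-fold higher number from compound 1 to compound 2 (0.12 log units; within the scatter), which was small. For the measured compounds named here, no measured pair speaks to the added fluorine of the 4-bromo-2-fluorophenyl group, so that part of the change is uncovered by the data.

On that basis the expectation for compound 4 in this assay is a step of a 1.3-fold higher number from compound 3 to compound 4 (0.12 log units; within the scatter), slight and within the scatter. Compound 4 is therefore estimated at 280 nM, with a range of 130 nM to 600 nM.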

Compound 4, half-maximal inhibitory concentration: 1630 nM
For compound 4 the middle estimate is 5.8-fold (0.77 log units) below the measured one; measured number outside the range, above it.
By their numbers in this assay, from the lowest: compounds 1, 3 and 2 (each within the scatter of the next); then compound 4.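

Among the compounds shown here, the position on the ring nitrogen proves less forgiving in this assay than the earlier compounds suggested: 4-bromo-2-fluorophenyl in place of 4-fluorophenyl gives a 7.8-fold higher number from compound 3 to compound 4 (0.89 log units; beyond the scatter), a step beyond the scatter and the first in this set to separate two compounds. The bromo-for-fluoro exchange on the non-methylated core, a 1.3-fold higher number from compound 1 to compound 2 (0.12 log units; within the scatter), stayed within the scatter, so that exchange as seen there does not match the size of the new step, which combines bromine with an added fluorine on the methylated core. Nothing measured here accounts for the size of this step.

As far as these compounds go, it remains open whether the added fluorine, the bromine or their combination on the methylated core carries the weakening. Also open, from the compounds shown here alone, is how this aryl ring would respond to a chloro group, a methoxy group or an amine.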